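From 2-methoxyethoxy to benzyloxy at an assay limit

The compounds below may be only part of what the source reports. "The series", "measured", "known", "first", "only" and "open" are said of these compounds alone.

Compound 1 `CC(C)CSc1nc(N)nc2c1ncn2/C=C1/CC1(CO)CO`, compound 2 `C=CCOc1nc(N)nc2c1ncn2/C=C1/CC1(CO)CO` and compound 3 `COCCOc1nc(N)nc2c1ncn2/C=C1/CC1(CO)CO` share a core and belong to one series tested in an ADME assay on MOLT-3 cells (Homo sapiens) for cytotoxicity, with a stated time of 7 days; on this read-out higher numbers stand for lower toxicity in this test and lower numbers for higher toxicity in this test. For compound 1 there is no result, recorded as "not determined" (no result reported). Compound 2 gives > 20000 nM, which is a limit of the assay and not a number. Compound 3 gives > 20000 nM, which is also a limit and not a number. Compound 3 therefore has no exact position in the series, and nothing ranks it against compound 2.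

Compound 4 `Nc1nc(OCc2ccccc2)c2ncn(/C=C3/CC3(CO)CO)c2n1` is still unmeasured. Its difference from compound 3 is phenyl in place of methoxymethyl on a saturated chain carbon bound to an oxygen on an aromatic ring. Seen one bond further out, 2-methoxyethoxy becomes benzyloxy.

Going by the values given here, the one measured step at this place is a step that the two limits leave unreadable from compound 2 to compound 3, so it offers no size to carry over. The remaining evidence is the limit of > 20000 nM in this assay, at which 2 of the 3 values shown sit. Neither compound 2 nor compound 3 carries a phenyl, so this guide is weak. In this assay, the expected step is a number no higher from compound 3 to compound 4 (the limit leaves the size open), with nothing expected beyond the usual scatter, though a lower number remains possible. Compound 4 is estimated at 20000 nM, with an expected range from 6000 nM to 50000 nM.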

Compound 4, half-maximal cytotoxic concentration: > 20000 nM
Compound 4 was reported as a limit; the forecaster's own chance of this, stated with the estimate: 65%; the middle value sits exactly at the limit.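

Going by these compounds alone, compound 2, compound 3 and compound 4 all stand at a limit in this assay and not at a number, and no step among them can be read. The compounds shown leave open whether phenyl, methoxymethyl and vinyl on this saturated chain carbon differ at all in this assay, and by how much.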